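Notes on a repeated methoxy change across two cores

The source may report more compounds than this note shows. Statements on the series, on what has been measured and on what is new or still open speak of the compounds shown alone.

Compound 1 `COc1ccc(C2CC(c3ccccc3)=NN2C2=NC(=O)/C(=C3\C(=O)Nc4ccc(Br)cc43)S2)cc1` and compound 2 `COc1ccc(C2=NN(C3=NC(=O)/C(=C4\C(=O)Nc5ccc(Br)cc54)S3)C(c3ccc(OC)cc3)C2)cc1` share one core; compound 3 `O=C1N=C(N2N=C(c3ccccc3)CC2c2ccc(Cl)cc2)S/C1=C1/C(=O)Nc2ccccc21` and compound 4 `COc1ccc(C2=NN(C3=NC(=O)/C(=C4\C(=O)Nc5ccccc54)S3)C(c3ccc(Cl)cc3)C2)cc1` share another, and the difference between the two cores is not broken down here. In a functional assay on cells (Leukemia cell, Homo sapiens) for cytotoxicity, read by sulforhodamine B assay, with a stated time of 48 h (on this read-out higher numbers stand for weaker inhibition of growth and lower numbers for stronger inhibition of growth), compound 1 gives 250 nM, and compound 2 gives 280 nM. The change between them, (methoxy in place of hydrogen on an aromatic carbon), gave a 1.1-fold higher number from compound 1 to compound 2 (0.05 log units; within the scatter). In this assay compound 3 gives 370 nM. Compound 4 differs from compound 3 by the same change, (methoxy in place of hydrogen on an aromatic carbon), at a place described in the same words. The expected step is a 1.1-fold higher number from compound 3 to compound 4 (0.03 log units; within the scatter), resting on how small the earlier step of a 1.1-fold higher number from compound 1 to compound 2 (0.05 log units; within the scatter) was. Compound 4 is therefore estimated at 400 nM in this assay, with a range from 200 nM to 800 nM. No wider pattern is claimed from two occurrences.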

Compound 4, concentration for 50% growth inhibition: 86600 nM
Estimate against measurement, compound 4: 220-fold (2.34 log units) below; the measured number lies above the stated range.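

In this assay, phenyl to 4-methoxyphenyl gave a 230-fold higher number from compound 3 to compound 4 (2.37 log units; beyond the scatter) on the core of compound 3, so the small step seen on the other core did not hold here. Within this series, the same change therefore did not carry from one core to the other: the same change on two cores in this assay, a 1.1-fold higher number (0.05 log units; within the scatter) from compound 1 to compound 2 and a 230-fold higher number (2.37 log units; beyond the scatter) from compound 3 to compound 4, 210-fold (2.32 log units) apart, beyond the scatter of two such steps
This rests on two pairs only; it does not show which difference between the two cores matters, and it gives no general rule for methoxy.

Still open, as far as these compounds go, is whether the large step is specific to methoxy or would also appear with an amine, a carboxylic acid or a longer chain at that place on the core of compound 3.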